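Methoxy for Fluoro on a Cytotoxicity Read-out

This account rests on a few compounds, and the source may have more. Where it says the series, first, only, none or still open, it means among the compounds named here.

Of the compounds shown here, three sharing one core have been tested in a functional assay on MCF7 cells (Homo sapiens) for cytotoxicity, read by MTT assay, with a stated time of 2 days, tested at 0.1 uM; on this read-out higher numbers stand for a weaker effect at the one concentration tested and lower numbers for a stronger effect. Compound 1 `CC(=O)c1cc(-c2ccccc2)cc2cc(-c3ccccc3)[nH]c12` gives 99.3%. Compound 2 `CC(=O)c1cc(-c2ccccc2)cc2cc(-c3ccc(F)cc3)[nH]c12`, which carries one fluoro group, gives 98.5% in this assay. Compound 3 `CC(=O)c1cc(-c2ccc(F)cc2)cc2cc(-c3ccc(F)cc3)[nH]c12`, which carries two fluoro groups, gives 99.8% in this assay. Compound 2 stands within the usual scatter of both other compounds: the step of a number 0.8 percentage points lower from compound 1 to compound 2 (within the scatter) and the step of a number 1.3 percentage points higher from compound 2 to compound 3 (within the scatter) are each too small to mean anything, so the three numbers are in effect the same, and all sit near the top of the scale, which means a weak effect at this concentration.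

Compound 4 `COc1ccc(-c2cc3cc(-c4ccccc4)cc(C(C)=O)c3[nH]2)cc1` is not yet measured. It differs from compound 2 in one place: methoxy in place of fluoro on an aromatic carbon. The two measured steps bear on this only loosely, since each exchanged a hydrogen for a fluoro rather than a fluoro for a methoxy, but both showed that a small change on a six-membered aromatic ring of carbon only left the read-out unmoved. On that basis no step beyond the scatter is expected in this assay. The expected step from compound 2 is no change at the digits printed from compound 2 to compound 4 (within the scatter). Compound 4 is therefore estimated at 98.5%, with a range from 93% to 102%.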

Compound 4, a percentage reported as activity, at one concentration (the size of the read-out at that concentration, not a potency): 87%
Compound 4: the middle estimate sits 11.5 percentage points above what was measured, outside the stated range (below it).
By their numbers in this assay, from the lowest: compound 4; then compounds 2, 1 and 3 (each within the scatter of the next).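

On the aromatic carbon para to a large group, methoxy in place of fluoro gives a number 11.5 percentage points lower from compound 2 to compound 4 (beyond the scatter) in this assay and so brings the first stronger effect in this set, a sign that this place can respond to what sits on it. Methoxy in place of hydrogen gives a number 12.3 percentage points lower from compound 1 to compound 4 (beyond the scatter) while fluoro in place of hydrogen on that same carbon gave only a number 0.8 percentage points lower from compound 1 to compound 2 (within the scatter) and thus the read-out separates methoxy from both hydrogen and fluoro but not those two from each other. No measurement offered here accounts for this shift.

Going by these compounds, whether the effect follows the oxygen alone or the whole methoxy group remains open, and a hydroxyl group, an ethoxy group or an amine on this carbon would help to settle that. Also open, on these data alone, is whether methoxy on the other six-membered aromatic ring of the shared core would act in the same way, and whether the stronger effect of compound 4 at this concentration holds at other concentrations, since a single concentration gives only the size of the effect at that concentration.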